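Compound 2 to compound 3: a swap on thin evidence

The source may hold more compounds than are shown below. What is called first, only, known or untested is meant among the compounds shown, and "the series" means these compounds.

Compound 1 `c1ccc(-c2nccnc2OC2CN(c3ccc4ccccc4n3)C2)cc1`: < 1000 nM
Compound 2 `c1ccc2nc(N3CC(Oc4nccnc4-c4ccc5scnc5c4)C3)ccc2c1`: < 1000 nM

In a physicochemical assay for solubility, in phosphate buffer, at pH 7.4 (on this read-out higher numbers stand for higher solubility and lower numbers for lower solubility), compound 2 stands at < 1000 nM, which is a limit and not a number. Compound 1 also gives only a limit, < 1000 nM. Compound 3 `COC(=O)N1CCC(c2nccnc2OC2CN(c3ccc4ccccc4n3)C2)CC1` has 1-(methoxycarbonyl)piperidin-4-yl in place of 1,3-benzothiazol-5-yl on an aromatic carbon. For the measured compounds named here, the one measured step that bears on this change is a step that the two limits leave unreadable from compound 1 to compound 2, where 1,3-benzothiazol-5-yl replaced phenyl. The evidence amounts to the limit of < 1000 nM in this assay, at which 2 of the 2 values shown sit. That step offers no size or direction to carry over, so no change beyond the usual scatter is expected in this assay. The expected change is a number no lower from compound 2 to compound 3 (the limit leaves the size open). For compound 3 the estimated value is 1000 nM, with an expected range from 300 nM to 4000 nM.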

Compound 3, solubility: 138000 nM
For compound 3 the middle estimate is 140-fold (2.14 log units) below the measured one, outside the stated range (above it).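

In this assay the earlier pair could show nothing about this position, and that step cannot be read, since both of its values are limits. Now the group on this aromatic carbon, next to the ring nitrogen, proves able to move the read-out a long way: 1-(methoxycarbonyl)piperidin-4-yl in place of 1,3-benzothiazol-5-yl gives a much higher number (an at least 130-fold higher number from compound 2 to compound 3 (2.13 log units; beyond the scatter)), and the same group in place of phenyl does too (an at least 130-fold higher number from compound 1 to compound 3 (2.13 log units; beyond the scatter)). The hydrogen-bond donor and acceptor counts of the leaving and entering groups in the first step match, and the full size of both steps stays open, as each starts from a limit: the limit of < 1000 nM in this assay, at which 2 of the 3 values shown sit.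

Going by these compounds, whether the non-aromatic ring or the methoxycarbonyl group carries the rise remains open. A plain cyclohexyl group, or a piperidin-4-yl group with a free ring amine, would help separate the two.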